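Saturating the ethenyl bridge toward a flexible two-carbon linker

The compounds below may be only part of what the source reports. "The series", "measured", "known", "first", "only" and "open" are said of these compounds alone.

Compound 2 `CCCCCCCCS(=O)(=O)Nc1ccc(/C=C/c2ccc(OC)cc2)cc1C(=O)O` gives 37100 nM in an assay on mitochondria (strain BALB/c) for inhibition of glycerol-3-phosphate acyltransferase 1, mitochondrial (Mus musculus), read by scintillation counting, with a stated time of 10 min; a higher number here means a weaker inhibitor, a lower number a stronger inhibitor. Compound 1 `CCCCCCCCS(=O)(=O)Nc1ccc(-c2ccc(O)cc2)cc1C(=O)O` gives 47300 nM in this assay, and the step of a 1.3-fold lower number from compound 1 to compound 2 (0.11 log units; within the scatter) shows that the two compounds sit within the scatter of each other, so compound 2 cannot be told apart from compound 1 on these numbers. Compound 3 `CCCCCCCCS(=O)(=O)Nc1ccc(CCc2ccc(OC)cc2)cc1C(=O)O` is the next step from compound 2: 2-(4-methoxyphenyl)ethyl in place of 2-(4-methoxyphenyl)ethenyl on an aromatic carbon. Among the compounds with values here, no measured pair turns the double bond of a two-carbon bridge into a single bond; the only measured step, from compound 1 to compound 2, changes the whole group that joins the two rings and stays within the scatter. On this basis a step of no more than the scatter is expected for compound 3 in this assay, with no preferred direction, expressed as a 1.0-fold lower number from compound 2 to compound 3 (0.00 log units; within the scatter). Compound 3 is therefore estimated at 37000 nM, within a range from 12000 nM to 110000 nM.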

Compound 3, half-maximal inhibitory concentration: 26300 nM
For compound 3 the middle estimate is 1.4-fold (0.15 log units) above the measured one; low and high end bracket the measured number.
By their numbers in this assay, from the lowest: compounds 3, 2 and 1 (each within the scatter of the next).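

With a 1.4-fold lower number from compound 2 to compound 3 (0.15 log units; within the scatter), removing the double bond from the 2-(4-methoxyphenyl)ethenyl group leaves the two compounds indistinguishable in this assay, so at this position, on an aromatic carbon para to a large group, the ethenyl and ethyl forms cannot be told apart on these numbers. The wider replacement of 4-hydroxyphenyl also stays within the scatter, with a 1.8-fold lower number from compound 1 to compound 3 (0.25 log units; within the scatter), and so none of the three groups at this position separates from the others. No evidence is available that bears on this result. Going by these compounds, whether another kind of group here, such as an amine, a carboxylic acid or a longer chain, would give a step beyond the scatter remains open. Also open, on these data alone, is what a hydroxy group in place of the methoxy of the 2-(4-methoxyphenyl)ethyl group would do.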